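Lengthening a Short Side Chain on a Sugar-Like Core

The compounds below may be only part of what the source reports. "The series", "measured", "known", "first", "only" and "open" are said of these compounds alone.

Compound 1 `CC(=O)O[C@@H]1[C@@H](OCc2ccccc2)[C@H](OCc2ccccc2)[C@@H](COCc2ccccc2)O[C@H]1C` is the anchor of this small set. In a functional assay on HOS cells (Homo sapiens) for antiproliferative activity, read by sulforhodamine B assay (a lower number here means a stronger inhibitor of growth, a higher number a weaker inhibitor of growth), compound 1 gives 8800 nM. Compound 2 `CC[C@@H]1O[C@H](COCc2ccccc2)[C@@H](OCc2ccccc2)[C@H](OCc2ccccc2)[C@H]1OC(C)=O` is the same molecule apart from one change: methyl in place of hydrogen on a saturated chain carbon bound to a saturated ring carbon. For compound 2 the result is a limit rather than a number, namely (the limit of > 50000 nM in this assay, at which 1 of the 3 values shown sits), reported as > 50000 nM. The change therefore produced an at least 5.6-fold higher number from compound 1 to compound 2 (0.75 log units; beyond the scatter).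

Compound 3 `CC[C@@H]1O[C@H](COCc2ccccc2)[C@@H](OCc2ccccc2)[C@H](OCc2ccccc2)C1=O` carries a different core; how its core differs from that of compound 1 is not broken down here. In this assay, among the measured compounds shown here, compound 3 gives 4300 nM, a lower number than compound 1 and the lowest of the two numbers measured so far.

Compound 4 `CCC[C@@H]1O[C@H](COCc2ccccc2)[C@@H](OCc2ccccc2)[C@H](OCc2ccccc2)C1=O` has not yet been measured. It differs from compound 3 by methyl in place of hydrogen on a saturated chain carbon, two bonds along the chain from a saturated ring carbon. For the measured compounds named here, this is the same kind of change as the one that turned compound 1 into compound 2, but not the same: there the methyl enters on a saturated chain carbon bound to a saturated ring carbon, whereas here it enters on a saturated chain carbon, two bonds along the chain from a saturated ring carbon. Beside the earlier at least 5.6-fold higher number from compound 1 to compound 2 (0.75 log units; beyond the scatter), the expectation is a step of a 4.7-fold higher number from compound 3 to compound 4 (0.67 log units; beyond the scatter), weaker on the same side, and this rests on an at least 5.6-fold higher number from compound 1 to compound 2 (0.75 log units; beyond the scatter) alone. Compound 4 is thus estimated to give about 20000 nM, most likely between 5000 nM and 60000 nM.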

Compound 4, concentration for 50% growth inhibition: > 50000 nM
Compound 4 gave a limit, no number; the forecaster's own chance of this, stated with the estimate: 30%; middle value at least 2.5-fold (0.39 log units) from the limit.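

Extending the ethyl chain to a propyl chain gave an at least 11-fold higher number from compound 3 to compound 4 (1.06 log units; beyond the scatter) in this assay, so on both cores shown, adding one methyl to the short side chain moved the result towards weaker inhibition of growth. Compound 2 and compound 4 each gave a limit and not a number, so each step has only a smallest possible size, and the two steps cannot be ranked against each other: the same change on two cores in this assay, an at least 5.6-fold higher number (0.75 log units; beyond the scatter) from compound 1 to compound 2 and an at least 11-fold higher number (1.06 log units; beyond the scatter) from compound 3 to compound 4; the limit leaves it open whether they differ. The direction of the change therefore carried over from the core of compound 1 to the core of compound 3, but its true size on either core remains unknown, and two cores, with the methyl entering at different places on the chain, are too few to establish a general rule: the limit of > 50000 nM in this assay, at which 2 of the 4 values shown sit.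

The compounds shown leave open whether a propyl chain on the core of compound 1 would behave as it does on the core of compound 3. They also leave open how a chain longer than propyl, or a short chain ending in an amine or a carboxylic acid, would read in this assay on either core.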